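Propyl to allyl: the step to compound 4

This account rests on a few compounds, and the source may have more. Where it says the series, first, only, none or still open, it means among the compounds named here.

In a functional assay on WHCO1 cells (Homo sapiens) for antiproliferative activity, read by MTT assay, with a stated time of 48 h (on this read-out higher numbers stand for weaker inhibition and lower numbers for stronger inhibition), compound 1 `C=CCSS/C=C/C[S+]([O-])CCC` gives 37000 nM, compound 2 `CCCSS/C=C\C[S+]([O-])CCC` gives 18000 nM and compound 3 `C=CCSS/C=C\C[S+]([O-])CCCOCc1ccc(OC)cc1` gives 21000 nM. Compound 2 stands level with compound 3, within the scatter, while compound 1 reads a higher number, beyond the scatter of compound 2. Compound 4 `C=CCSS/C=C\C[S+]([O-])CCC` departs from compound 2 in one place: vinyl in place of ethyl on a saturated chain carbon bound to a sulfur. Among the measured compounds shown here, no measured pair shows this change alone. Compound 3, which also carries allylsulfanyl, gives 21000 nM, level with compound 2, so no shift beyond the scatter is expected in this assay. The expected 1.2-fold higher number from compound 2 to compound 4 (0.09 log units; within the scatter) is small. For compound 4 the estimated value is 22000 nM, with an expected range from 11000 nM to 42000 nM.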

Compound 4, half-maximal inhibitory concentration: 23000 nM
Compound 4: the middle estimate sits 1.0-fold (0.02 log units) below what was measured; measured number inside the range.
By their numbers in this assay, from the lowest: compounds 2, 3, 4 and 1 (each within the scatter of the next, the first and the last beyond it).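

In this assay, the change from propyl to allyl now stands alone, and it gives a 1.3-fold higher number from compound 2 to compound 4 (0.11 log units; within the scatter), so vinyl in place of ethyl on a saturated chain carbon bound to a sulfur leaves the two compounds level. Among the compounds shown here, the double bond drawn E or Z can also be read by itself for the first time, with a 1.6-fold lower number from compound 1 to compound 4 (0.21 log units; within the scatter). That second pair carries a caution: the fact that one of compounds 1 and 4 is drawn with a defined configuration and the other without, at the place where they differ

The compounds shown leave open whether a longer chain or an amine in this place would move the number beyond the scatter.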